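Sulfonyl aryl variation in the anilide series

The source may report more compounds than this note shows. Statements on the series, on what has been measured and on what is new or still open speak of the compounds shown alone.

Compound 2 `CCN(CC)C(=O)CN(c1ccc(C)cc1)S(=O)(=O)c1ccc(C#N)cc1` carries a 4-cyanophenyl on the sulfonyl sulfur; in a functional assay on CHO cells for inhibition of Orexin/Hypocretin receptor type 1 (Homo sapiens), read by FLIPR and calcium flux (on this read-out higher numbers stand for weaker inhibition and lower numbers for stronger inhibition), compound 2 gives only a limit, > 10000 nM. Compound 1 `CCN(CC)C(=O)CN(c1ccc(C)cc1)S(=O)(=O)c1ccc(OC(F)(F)F)cc1` likewise returns a limit in this assay, > 10000 nM. Compound 3 `CCN(CC)C(=O)CN(c1ccc(C)cc1)S(=O)(=O)c1ccc(C(C)(C)C)cc1` also sits at a limit in this assay, > 10000 nM. All three values therefore sit together at the limit of > 10000 nM in this assay, at which 3 of the 3 values shown sit, and the steps a step that the two limits leave unreadable from compound 1 to compound 2, a step that the two limits leave unreadable from compound 1 to compound 3 and a step that the two limits leave unreadable from compound 2 to compound 3 cannot be sized from them.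

Compound 4 `CCN(CC)C(=O)CN(c1ccc(C)cc1)S(=O)(=O)c1ccccc1C` replaces the aryl on the sulfonyl sulfur: 2-methylphenyl in place of 4-cyanophenyl on a sulfonyl sulfur. Among the compounds with values here, no measured step shows how this part of the molecule moves this assay; the series so far only shows that three different groups at this place all stay beyond the limit. With nothing pointing to a gain, the expected step of a number no higher from compound 2 to compound 4 (the limit leaves the size open) is set at none, with the outcome most likely to be a limit once more. Compound 4 is accordingly expected near 10000 nM, within 3000 nM to 30000 nM.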

Compound 4, half-maximal inhibitory concentration: > 10000 nM
Compound 4 ended at the assay's limit; the forecaster's own chance of this, stated with the estimate: 75%; the middle value lies on the limit itself.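

Compound 2 and compound 4 both return only limits in this assay, so no step between them can be read: the limit of > 10000 nM in this assay, at which 4 of the 4 values shown sit.

The compounds shown leave open whether any group on the sulfonyl sulfur gives a measurable inhibition in this assay, and how these four compounds compare.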